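A few compounds are considered here, and "the series" means these few. Any claim that something is new, unique, unknown or untested is made for them only; others in the source may bear on it.

Measured so far:
Compound 1, `O=C(Nc1ccccc1F)c1cccc2[nH]c(-c3ccncc3)nc12`: 111 uM
Compound 2, `O=C(Nc1ccccc1F)c1cccc2[nH]c(-c3ccco3)nc12`: 25 uM

In an ADME assay on Vero cells (Chlorocebus sabaeus) for cytotoxicity (a higher number here means that more compound is tolerated, a lower number that less compound is tolerated), compound 1 gives 111 uM, and compound 2 gives 25 uM. Among the compounds with values here, compound 2 holds the lowest of the two numbers seen here; the single step available, a 4.4-fold lower number from compound 1 to compound 2 (0.65 log units; beyond the scatter), shows that swapping the ring on the shared core already moved the number beyond the scatter. Compound 3, `O=C(Nc1ccccc1F)c1cccc2[nH]c(-c3ccc([N+](=O)[O-])o3)nc12`, has not yet been tested. It differs from compound 2 by nitro in place of hydrogen on an aromatic carbon. Within the data shown here, no measured step touches this exact change, so the step from compound 1 to compound 2 bears on it only loosely, as a sign that this part of the molecule can shift the read-out. On that thin basis a further modest fall toward less tolerance is expected for compound 3, amounting to a 1.8-fold lower number from compound 2 to compound 3 (0.25 log units; within the scatter). The expected value for compound 3 in this assay is therefore 14 uM, with a likely range from 5 uM to 45 uM.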

Compound 3, half-maximal toxic concentration: 75.9 uM
For compound 3 the middle estimate is 5.4-fold (0.73 log units) below the measured one, and the stated range ends below it.
By their numbers in this assay, from the lowest: compound 2; then compounds 3 and 1 (each within the scatter of the next).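

Adding nitro to the furan, on the aromatic carbon next to the ring oxygen, gives a 3.0-fold higher number from compound 2 to compound 3 (0.48 log units; beyond the scatter) in this assay, so this read-out responds to a single group on the furan and not only to an exchange of the whole ring. With 5-nitrofuran-2-yl in place of pyridin-4-yl there is a 1.5-fold lower number from compound 1 to compound 3 (0.17 log units; within the scatter), so a furan at this position does not always come with the low number of compound 2. Nothing available explains why the nitro group has this effect.

From the compounds shown here alone, whether an amine or a carboxylic acid on the same furan carbon would shift the number in the same direction remains open. So does whether nitro would act similarly on the pyridin-4-yl ring of compound 1.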